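The source may report more compounds than this note shows. Statements on the series, on what has been measured and on what is new or still open speak of the compounds shown alone.

Among the three compounds with numbers in hand, compound 3, whose structure is `OC[C@H]1O[C@@H](n2cnc3c(CSc4c(F)cccc4Cl)ncnc32)[C@H](O)[C@@H]1O`, stands at the low end: in an assay on isolated protein for binding affinity to Equilibrative nucleoside transporter 1 (Homo sapiens) (on this read-out lower numbers stand for stronger inhibition and higher numbers for weaker inhibition), compound 3 gives 1510 nM. Compound 1, with structure `Nc1nc(SCc2ccccc2[N+](=O)[O-])c2ncn([C@@H]3O[C@H](CO)[C@@H](O)[C@H]3O)c2n1`, is its nearest neighbour, and in this assay compound 1 gives 4570 nM, a difference that exceeds the usual scatter. Compound 2, with structure `OC[C@H]1O[C@@H](n2cc(I)c3c(Cl)ncnc32)[C@H](O)[C@@H]1O`, lies far behind the other two: in this assay compound 2 gives 77600 nM.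

The next compound to be measured is compound 4, whose structure is `COc1ccc(SCc2ncnc3c2ncn3[C@@H]2O[C@H](CO)[C@@H](O)[C@H]2O)cc1`. It differs from compound 3 in a single place: 4-methoxyphenyl in place of 2-chloro-6-fluorophenyl on a sulfur. The rest of the molecule, including the sugar and the shared core, is unchanged.

Among the measured compounds shown here, no pair of compounds with numbers differs in only this one place, so there is no directly comparable step to lean on. What the three numbers do show is that this series spans a wide range and that changes on the ring attached to the sulfur can matter. On that basis a modest loss is expected, with the step from compound 3 to compound 4 estimated at a 1.7-fold higher number from compound 3 to compound 4 (0.22 log units; within the scatter), a size that may still fall inside the scatter. Compound 4 is accordingly expected to give about 2500 nM in this assay, with a plausible range from 700 nM to 9000 nM.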

Compound 4, half-maximal inhibitory concentration: 617 nM
Estimate against measurement, compound 4: 4.1-fold (0.61 log units) above, outside the stated range (below it).
By their numbers in this assay, from the lowest: compound 4; then compound 3; then compound 1; then compound 2.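

A single swap on the ring attached to the sulfur moves the number in this assay: putting 4-methoxyphenyl in place of 2-chloro-6-fluorophenyl gives a 2.4-fold lower number from compound 3 to compound 4 (0.39 log units; beyond the scatter) and this modest step lies beyond the usual scatter. Among the compounds shown here, it is the first direct comparison in this set of compounds, and it shows that the chlorine and fluorine of compound 3 are not needed on this ring for a low number, as compound 4 carries neither of them and still gives the lower number of the pair. Nothing available here explains why the 4-methoxyphenyl ring gives the lower number.

On these data alone, the swap removes the chlorine and fluorine and adds the methoxy group in one step, so it remains open whether the gain belongs to the new group, to the loss of the old ones, or to both, and a plain phenyl ring would help separate these. Also open, as far as these compounds go, is how this assay would respond to an amine or a carboxylic acid on this ring, or to a longer chain such as ethoxy in place of methoxy.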